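One Change in the Side Arm of Compound 1

The source may hold more compounds than are shown below. What is called first, only, known or untested is meant among the compounds shown, and "the series" means these compounds.

Measured so far:
Compound 1, `CN(Cc1ccc(C(=O)O)cc1)c1ccc(OCc2c(-c3c(Cl)cccc3Cl)noc2C2CC2)nc1C(F)(F)F`: 109% in an assay on isolated protein for agonist activity at Bile acid receptor (Homo sapiens), read by FRET; on this read-out higher numbers stand for larger maximal responses and lower numbers for smaller maximal responses
Compound 2, `CCN(Cc1ccc(C(=O)O)cc1)c1ccc(OCc2c(-c3c(Cl)cccc3Cl)noc2C2CC2)nc1C(F)(F)F`: 94% in this assay

Compound 1 holds the higher of the two numbers; compound 2 sits a number 15 percentage points lower from compound 1 to compound 2 (beyond the scatter). Compound 3, `O=C(O)c1cccc(OCc2ccc(OCc3c(-c4c(Cl)cccc4Cl)noc3C3CC3)nc2C(F)(F)F)c1`, is not yet measured. It differs from compound 1 by (3-carboxyphenoxy)methyl in place of (4-carboxybenzyl)(methyl)amino on an aromatic carbon. Among the measured compounds shown here, no measured step covers this change directly. For the measured compounds named here, the only step known, a number 15 percentage points lower from compound 1 to compound 2 (beyond the scatter), shows that a small alteration in this part of compound 1 already shifted the response beyond the scatter, so the larger alteration in compound 3 is expected to shift it further, most likely downward, by a number 24 percentage points lower from compound 1 to compound 3 (beyond the scatter). Compound 3 is therefore estimated at 85%, within a range from 50% to 115%.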

Compound 3, largest response reached (reported as efficacy), in percent of the reference or control that the assay uses: 98%
Beside the measured number, compound 3's estimate is 13 percentage points below it; the measured number falls inside the stated range.
By their numbers in this assay, from the lowest: compounds 2 and 3 (each within the scatter of the next); then compound 1.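

Swapping the entire side arm, rather than one small part of it, still leaves a large response in this assay (a number 11 percentage points lower from compound 1 to compound 3 (beyond the scatter)). At this position, the nitrogen of (4-carboxybenzyl)(methyl)amino is therefore not needed for a large response, and (3-carboxyphenoxy)methyl can stand in its place. No evidence here explains this result.

Among the compounds shown here, the single step changes the linking atoms and the place of the carboxylic acid on the ring together, so their separate contributions remain open. Also open, going by these compounds, is how a tetrazole in place of the carboxylic acid would fare.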